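Chloro Added Between Ring Nitrogens of Compound 2

This account rests on a few compounds, and the source may have more. Where it says the series, first, only, none or still open, it means among the compounds named here.

Measured compounds:
compound 1 `ClCc1ccccc1Cn1cnc2c(Cl)nc(Cl)nc21` — 5750 nM
compound 2 `ClCc1cccc(Cn2cnc3ncnc(Cl)c32)c1` — 67600 nM

In a functional assay on M14 cells (Homo sapiens) for cytotoxicity, read by sulforhodamine B assay, with a stated time of 48 h (a lower number here means that less compound is tolerated, a higher number that more compound is tolerated), compound 2 gives the higher of the two numbers, and the step down to compound 1 lies beyond the scatter. Compound 3 `ClCc1cccc(Cn2cnc3nc(Cl)nc(Cl)c32)c1` differs from compound 2 by chloro in place of hydrogen on an aromatic carbon. Within the data shown here, no measured pair shows this change alone, so its size is uncertain; compound 1, which carries the same chloro but a differently placed chloromethyl, gives 5750 nM. Compound 3 is therefore expected to tolerate less compound than compound 2, a step of a 3.4-fold lower number from compound 2 to compound 3 (0.53 log units; beyond the scatter), giving an estimated 20000 nM with a range from 5000 nM to 80000 nM.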

Compound 3, concentration lethal to 50% of the cells: 5120 nM
Beside the measured number, compound 3's estimate is 3.9-fold (0.59 log units) above it; low and high end bracket the measured number.
By their numbers in this assay, from the lowest: compounds 3 and 1 (each within the scatter of the next); then compound 2.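

In this assay, among these compounds, chloro in place of hydrogen on the aromatic carbon between two ring nitrogen atoms gives a 13-fold lower number from compound 2 to compound 3 (1.12 log units; beyond the scatter), the first direct reading of this change alone. With this chloro present, compound 1 and compound 3 lie within the scatter of each other, although their chloromethyl groups are placed differently. Nothing available bears on what lies behind the step.

As far as these compounds go, whether an amine or a methoxy group at this position would give a similar step remains open. So does whether removing this chloro from compound 1 would give a step of the same size.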